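The compounds below may be only part of what the source reports. "The series", "measured", "known", "first", "only" and "open" are said of these compounds alone.

Three compounds have been measured so far:

Compound 1, `Cc1ccc(C)c(S(=O)(=O)n2c(-c3cn(-c4ccccc4)nc3-c3ccc(F)cc3)nc3ccccc32)c1`, gives 320 nM.
Compound 2, `O=[N+]([O-])c1ccc(S(=O)(=O)n2c(-c3cn(-c4ccccc4)nc3-c3ccc(F)cc3)nc3ccccc32)cc1`, gives 1170 nM.
Compound 3, `Cc1ccc(C)c(S(=O)(=O)n2c(-c3cn(-c4ccccc4)nc3-c3ccc(C(F)(F)F)cc3)nc3ccccc32)c1`, gives 210 nM.

All three values come from a functional assay on HeLa cells (Homo sapiens) for antiproliferative activity, read by MTT assay, with a stated time of 24 h; on this read-out lower numbers stand for stronger inhibition and higher numbers for weaker inhibition. Compound 1 and compound 2 share a core and differ by one change, (4-nitrophenyl in place of 2,5-dimethylphenyl on a sulfonyl sulfur), and that change produced a 3.7-fold higher number from compound 1 to compound 2 (0.56 log units; beyond the scatter). Compound 3 differs from compound 1 at the other end of the molecule, by trifluoromethyl in place of fluoro on an aromatic carbon, and this gave a 1.5-fold lower number from compound 1 to compound 3 (0.18 log units; within the scatter), so compound 1 and compound 3 cannot be told apart on this read-out. Compound 2 stands apart from compound 3 by a gap that is beyond the scatter.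

Compound 4, `O=[N+]([O-])c1ccc(S(=O)(=O)n2c(-c3cn(-c4ccccc4)nc3-c3ccc(C(F)(F)F)cc3)nc3ccccc32)cc1`, has not been measured. It differs from compound 3 by 4-nitrophenyl in place of 2,5-dimethylphenyl on a sulfonyl sulfur. The place is described in the same words as for the change from compound 1 to compound 2, so this is the same change, now made on the core of compound 3. Among the compounds with values here, the only guide to its effect is the earlier instance, a 3.7-fold higher number from compound 1 to compound 2 (0.56 log units; beyond the scatter). Compound 4 is therefore expected to lie at a weaker level than compound 3 by about a 3.7-fold higher number from compound 3 to compound 4 (0.57 log units; beyond the scatter), a step of the same size as the earlier one. Starting from compound 3 at 210 nM, compound 4 is estimated at 780 nM, with the likely range running from 350 nM to 1800 nM.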

Compound 4, half-maximal inhibitory concentration: 950 nM
Compound 4: middle estimate off by 1.2-fold (0.09 log units), on the low side; the measured number falls inside the stated range.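

In this assay, 4-nitrophenyl in place of 2,5-dimethylphenyl on a sulfonyl sulfur gave a 4.5-fold higher number from compound 3 to compound 4 (0.66 log units; beyond the scatter), and this step on the core of compound 3 agrees with the one on the core of compound 1: the same change on two cores in this assay, a 3.7-fold higher number (0.56 log units; beyond the scatter) from compound 1 to compound 2 and a 4.5-fold higher number (0.66 log units; beyond the scatter) from compound 3 to compound 4, 1.2-fold (0.09 log units) apart, within the scatter of two such steps
The other change, trifluoromethyl in place of fluoro on an aromatic carbon, stayed within the scatter at a 1.2-fold lower number from compound 2 to compound 4 (0.09 log units; within the scatter), and it behaved alike whichever group sat on the sulfonyl sulfur: the same change on two cores in this assay, a 1.5-fold lower number (0.18 log units; within the scatter) from compound 1 to compound 3 and a 1.2-fold lower number (0.09 log units; within the scatter) from compound 2 to compound 4, 1.2-fold (0.09 log units) apart, within the scatter of two such steps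
Across these four compounds, then, each change carried over from one core to the other at about the same size, but this rests on a single pair of instances per change in one cell read-out, on cores that differ only by these same two groups, so it does not show that the steps would hold on a more distant core, and it gives no reason for them.

From the compounds shown here alone, it remains open whether the step would hold for other groups on the sulfonyl sulfur, such as an aminophenyl ring or a simple methyl. Going by these compounds, it is equally open whether a methoxy group or a carboxylic acid in place of fluoro or trifluoromethyl on that aromatic carbon would move the number beyond the scatter.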